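This account rests on a few compounds, and the source may have more. Where it says the series, first, only, none or still open, it means among the compounds named here.

Compound 3, `COc1cc(NC(=O)Nc2cc(Nc3ccc(OC)c(I)c3)ncn2)cc(OC)c1`, gives 43% in a functional assay on NCI-H1581 cells (Homo sapiens) for inhibition, read by MTT assay, with a stated time of 48 h, tested at 10 uM; a higher number here means more inhibition at the concentration tested (going by the name of the read-out), a lower number less inhibition. Among the three measured compounds it ranks second, but its gap to compound 1, `COc1cc(NC(=O)Nc2cc(Nc3cccc(C(C)(C)C)c3)ncn2)cc(OC)c1`, which gives 35.1% in this assay, is within the scatter, so the two cannot be told apart; compound 2, `O=C(Nc1cc(Nc2ccc(F)c(Cl)c2)ncn1)Nc1c(Cl)cccc1Cl`, gives 67% in this assay and lies beyond the scatter above compound 3.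

The new compound 4, `CCc1ccc(Nc2cc(NC(=O)Nc3cc(OC)cc(OC)c3)ncn2)cc1`, differs from compound 3 by 4-ethylphenyl in place of 3-iodo-4-methoxyphenyl on a nitrogen on an aromatic ring. Among the compounds with values here, one measured step bears on this kind of change, because it also swaps the group on that same nitrogen: a number 7.9 percentage points higher from compound 1 to compound 3 (within the scatter), a difference that stays within the scatter. Within the data shown here, with only that guide, the swap to 4-ethylphenyl is expected to move the read-out little, in no clear direction. Compound 4 is therefore estimated at 39% in this assay, with a range from 22% to 56%, which means an expected step of a number 4 percentage points lower from compound 3 to compound 4 (within the scatter).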

Compound 4, a percentage reported as inhibition, at one concentration (the size of the read-out at that concentration, not a potency): 32.7%
Compound 4: middle estimate off by 6.3 percentage points, on the high side, and the stated range covers the measured number.
By their numbers in this assay, from the lowest: compounds 4, 1 and 3 (each within the scatter of the next, the first and the last beyond it); then compound 2.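

Within the data shown here, at the nitrogen on an aromatic ring, the choice of group now makes a measurable, if modest, difference in this assay: 4-ethylphenyl in place of 3-iodo-4-methoxyphenyl gives a number 10.3 percentage points lower from compound 3 to compound 4 (beyond the scatter), the first step at this position to clear the scatter. Against 3-(tert-butyl)phenyl, the same 4-ethylphenyl group gives a number 2.4 percentage points lower from compound 1 to compound 4 (within the scatter), so compound 1 and compound 4 cannot be told apart, and compound 3 stands apart from compound 4 but not from compound 1. No measurement here explains why the read-out shifts with this change.

Still open, going by these compounds, is whether a phenyl ring carrying an amine or a carboxylic acid would behave like these groups. Each reading also comes from a single concentration, so the potency of these compounds remains unknown.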